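Compound 1 gains a methoxy group

This account rests on a few compounds, and the source may have more. Where it says the series, first, only, none or still open, it means among the compounds named here.

Compound 1 `COc1ccc(C(=O)N2CCN(CC(=O)N3CCN(CCCc4c[nH]c5ccccc45)CC3)CC2)cc1` gives 156000 nM 
Compound 2 `COc1cccc(C(=O)N2CCN(CC(=O)N3CCN(CCCc4c[nH]c5ccccc45)CC3)CC2)c1` gives 143000 nM 
Compound 3 `O=C(CN1CCN(C(=O)c2ccccc2F)CC1)N1CCN(CCCc2c[nH]c3ccccc23)CC1` gives 133000 nM 

These three values come from an ADME assay on HEK293 cells (Homo sapiens) for cytotoxicity, read by MTT assay, with a stated time of 72 h (on this read-out lower numbers stand for stronger inhibition and higher numbers for weaker inhibition), and compound 1 stands level with compounds 2 and 3, with every gap among them inside the scatter. Compound 4 `COc1ccc(C(=O)N2CCN(CC(=O)N3CCN(CCCc4c[nH]c5ccc(OC)cc45)CC3)CC2)cc1` differs from compound 1 in one place, where 1H-indol-3-yl becomes 5-methoxy-1H-indol-3-yl: methoxy in place of hydrogen on an aromatic carbon 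

The nearest evidence is two swaps of the group on the carbonyl carbon, a 1.1-fold lower number from compound 1 to compound 2 (0.04 log units; within the scatter) and a 1.2-fold lower number from compound 1 to compound 3 (0.07 log units; within the scatter) and both stayed within the scatter. Neither tests a change on the indole, so this evidence is indirect. No step beyond the scatter is expected, and the estimated step is a 1.2-fold lower number from compound 1 to compound 4 (0.08 log units; within the scatter) in this reading. For compound 4 the estimated value is 130000 nM with 60000 nM to 250000 nM as the expected range.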

Compound 4, half-maximal inhibitory concentration: 190000 nM
Compound 4: middle estimate off by 1.5-fold (0.16 log units), on the low side; measured number inside the range.
By their numbers in this assay, from the lowest: compounds 3, 2, 1 and 4 (each within the scatter of the next).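

Among the compounds shown here, for the first time the 1H-indol-3-yl end of the molecule is altered rather than the group on the carbonyl carbon, and methoxy in place of hydrogen on an aromatic carbon gives a 1.2-fold higher number from compound 1 to compound 4 (0.09 log units; within the scatter) in this assay. So at this place on the fused ring system, compound 4 stands level with compound 1, and this methoxy leaves the cell read-out where it was. Nothing measured here accounts for this result.

Only this one group at this one place is shown. Going by these compounds, an amine, a carboxylic acid or a longer alkoxy chain there remains open, as does methoxy on the other carbons of that ring.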